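The compounds below may be only part of what the source reports. "The series", "measured", "known", "first", "only" and "open" are said of these compounds alone.

Compound 1 `COc1ccc(-c2cc(-c3ccc(S(=O)(=O)NC4CC4)cc3)cnc2N)cn1` was examined in an in vitro ADME assay on microsomes from liver (Homo sapiens) for metabolic stability (on this read-out lower numbers stand for a shorter-lived compound and higher numbers for a longer-lived compound), where compound 1 gives 1.9 h. Of the two plain numbers shown, this is the lower one, but the neighbouring number is close: compound 3 `COc1ccc(-c2cc(-c3ccc4nccn4c3)cnc2N)cn1` gives 2.43 h, and the gap to compound 1 lies within the usual scatter, so the two cannot be told apart. Compound 2 `COc1ccc(-c2cc(-c3ccc(S(C)(=O)=O)cc3C(F)(F)F)cnc2N)cn1` returns only a limit of this assay, > 4.16 h, and is counted as such (the limit of > 4.16 h in this assay, at which 1 of the 3 values shown sits). Compound 4 `COc1ccc(-c2cc(-c3ccc(C(=O)O)cc3)cnc2N)cn1` has not yet been measured and differs from compound 1 in a single place: carboxy in place of cyclopropylsulfamoyl on an aromatic carbon. Within the data shown here, no measured pair traces this exchange, so its effect in this assay rests on expectation alone. A modest lengthening beyond the scatter is expected for compound 4, and the step from its parent is expected to be a 1.6-fold higher number from compound 1 to compound 4 (0.20 log units; within the scatter). On that basis compound 4 is estimated at 3 h, with a likely range from 1.4 h to 6 h.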

Compound 4, half-life: > 4.16 h
Compound 4 was reported as a limit; the forecaster's own chance of this, stated with the estimate: 30%; middle value at least 1.3-fold (0.14 log units) away from the limit.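

In this assay, among these compounds, carboxy in place of cyclopropylsulfamoyl gives an at least 2.1-fold higher number from compound 1 to compound 4 (0.34 log units; beyond the scatter), the first step at this position that can be read, and it lies beyond the scatter. The change therefore shows that this aromatic carbon, para to a large group, is a place where a single exchange moves the half-life by more than repeat measurements would. Compound 4 returns only a limit of the assay, so the step gives a minimum and not a full size, and the read-out now ends at the same limit for two compounds: the limit of > 4.16 h in this assay, at which 2 of the 4 values shown sit.

The compounds shown do not tell whether the longer half-life comes with carboxy itself or with the loss of cyclopropylsulfamoyl. They also leave open whether a carboxamide or a methyl ester in the same place would give a similar step.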